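Trimethoxybenzyl ether series: phenol replaced by trimethoxyphenyl

The compounds below may be only part of what the source reports. "The series", "measured", "known", "first", "only" and "open" are said of these compounds alone.

Measured so far:
compound 1, `CCOC(=O)c1ccc(OCc2cc(OC)c(OC)c(OC)c2)cc1`: > 100 ug/mL
compound 2, `COc1cc(/C=N/NC(=O)c2ccc(OCc3cc(OC)c(OC)c(OC)c3)cc2)cc(OC)c1O`: 75 ug/mL

For the measured compounds named here, in a physicochemical assay, with a stated time of 30 min (on this read-out lower numbers stand for stronger inhibition and higher numbers for weaker inhibition), compound 2 gives 75 ug/mL, the only numeric value in the set. Compound 1 gives > 100 ug/mL, which is a limit of the assay and not a number. Compound 2 therefore stands as the single point of reference, with the other entry sitting at the limit of > 100 ug/mL in this assay, at which 1 of the 2 values shown sits.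

Compound 3, `COc1cc(COc2ccc(C(=O)N/N=C/c3ccc(OC)c(OC)c3OC)cc2)cc(OC)c1OC`, is not yet measured. The change from compound 2 to compound 3 is 2,3,4-trimethoxyphenyl in place of 4-hydroxy-3,5-dimethoxyphenyl on a carbon with a double bond to nitrogen; in words, 2,3,4-trimethoxyphenyl in place of 4-hydroxy-3,5-dimethoxyphenyl on a carbon with a double bond to nitrogen. The group that leaves carries one hydrogen-bond donor, the group that enters carries none. Going by the values given here, no measured step between two compounds that differ in one place exists in this set, so the size of the step can only be expected, not read off. Compound 1 likewise carries no hydrogen-bond donor and in this assay gives > 100 ug/mL, a limit of the assay. A weakening beyond the usual scatter is expected, a 2.0-fold higher number from compound 2 to compound 3 (0.30 log units; within the scatter), with a fair chance that only a limit is reported. Compound 3 is estimated at 150 ug/mL, in the range 60 ug/mL to 400 ug/mL.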

Compound 3, half-maximal inhibitory concentration: > 100 ug/mL
Compound 3 gave a limit, no number; the forecaster's own chance of this, stated with the estimate: 60%; the middle value is on the limit's open side.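

In this assay, 2,3,4-trimethoxyphenyl in place of 4-hydroxy-3,5-dimethoxyphenyl on a carbon with a double bond to nitrogen gives an at least 1.3-fold higher number from compound 2 to compound 3 (0.12 log units; that floor lies within the scatter). For the compounds shown here, this is the first comparison between compounds that differ in one place, but compound 3 gives only a limit of the assay, not a number, so the real size of the step stays unknown and its floor does not establish a change beyond the usual scatter. Compound 2 remains the only compound in the set with a number, and the other entries sit at a limit: the limit of > 100 ug/mL in this assay, at which 2 of the 3 values shown sit.

The step removes the hydrogen-bond donor of the leaving group and alters the pattern of methoxy groups at once, so the result cannot assign the outcome to either change alone. Also open, going by these compounds, is how an amine or a carboxylic acid in place of the hydroxy group of compound 2 would read in this assay.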